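The compounds below may be only part of what the source reports. "The series", "measured", "known", "first", "only" and "open" are said of these compounds alone.

Values from an ADME assay on HEK-293T cells (Homo sapiens) for inhibition, read by CCK-8 assay, with a stated time of 48 h, tested at 20 uM (on this read-out higher numbers stand for more inhibition of growth at the one concentration tested and lower numbers for less inhibition of growth), for three compounds:
- compound 1 `COc1ccc(S(=O)(=O)Oc2ccccc2/C=C(\C#N)C(=O)Nc2nnc(Cc3cccc(F)c3)s2)cc1` gives 29%
- compound 2 `N#C/C(=C\c1ccccc1OS(=O)(=O)c1ccccc1[N+](=O)[O-])C(=O)Nc1nnc(Cc2cccc(F)c2)s1` gives "not toxic" (no number reported)
- compound 3 `N#C/C(=C\c1ccccc1OS(=O)(=O)c1ccc(F)cc1)C(=O)Nc1nnc(Cc2cccc(F)c2)s1` gives 17%

Of the two actual numbers, compound 3 at 17% is the lower one, and compound 2 offers no number to compare. Next comes compound 4 `Cc1ccc(Cc2nnc(NC(=O)/C(C#N)=C/c3ccccc3OS(=O)(=O)c3ccc(F)cc3)s2)cc1`, which differs from compound 3 in one place: 4-methylphenyl in place of 3-fluorophenyl on a saturated chain carbon bound to an aromatic carbon with 4-methylphenyl in place of 3-fluorophenyl on a saturated chain carbon bound to an aromatic carbon. Among the compounds with values here, the only measured step, a number 12 percentage points lower from compound 1 to compound 3 (beyond the scatter), sits elsewhere in the molecule, so it says little about this change. Within the data shown here, no measured step touches the 3-fluorophenyl group, which leaves no firm ground for predicting a shift in this assay in either direction. The expected change is a number 3 percentage points higher from compound 3 to compound 4 (within the scatter), which would stay within the usual scatter. For compound 4 the estimated value is 20%, with an expected range from 6% to 36% on this reasoning.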

Compound 4, percent growth inhibition at one concentration: 11%
For compound 4 the middle estimate is 9 percentage points above the measured one, and the stated range covers the measured number.
By their numbers in this assay, from the lowest: compounds 4 and 3 (each within the scatter of the next); then compound 1.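

In this assay, within the data shown here, putting 4-methylphenyl in place of 3-fluorophenyl on a saturated chain carbon bound to an aromatic carbon gives a number 6 percentage points lower from compound 3 to compound 4 (within the scatter), the first reading at this position. Within this pair, then, the exchange of one aromatic group for the other leaves the read-out inside the usual scatter, whereas the earlier step concerned a different part of the molecule. Nothing available here bears on the reason for this result.

The pair alters both the substituent and the number in the group's name at once, so 3-methylphenyl or 4-fluorophenyl would be needed to tell those two differences apart. Going by these compounds, it also remains open whether a group of another kind at this position, such as an amine or a carboxylic acid, would give a step beyond the scatter.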